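Removing the Chloro Group in a Sulfonylurea Aorta Series

The source may report more compounds than this note shows. Statements on the series, on what has been measured and on what is new or still open speak of the compounds shown alone.

Measured so far in a functional assay on thoracic aorta (Rattus norvegicus, strain Wistar), with a stated time of 15 min; a lower number here means that less compound is needed, a higher number that more compound is needed for the effect:
compound 1, `CC(NC(=O)NS(=O)(=O)c1ccc(Cl)cc1)c1ccccc1OCc1ccccc1`, gives 157000 nM.
compound 2, `Cc1ccc(OCc2ccccc2)c(C(C)NC(=O)N(C)S(=O)(=O)c2ccc(Cl)cc2)c1`, gives 142000 nM.
compound 3, `CC(NC(=O)NS(=O)(=O)c1ccccc1)c1ccccc1OCc1ccccc1`, reaches only a limit of the assay, recorded as > 200000 nM.

Compound 1 and compound 3 differ in a single place: hydrogen in place of chloro on an aromatic carbon. That change produced an at least 1.2-fold higher number from compound 1 to compound 3 (0.10 log units; that floor lies within the scatter), and compound 3 sits at the limit of > 200000 nM in this assay, at which 1 of the 3 values shown sits. Compound 2 lies close to compound 1 in this assay, within the usual scatter, so no order between the two can be read. The difference between the cores of compound 1 and compound 2 is not broken down here.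

Compound 4, `Cc1ccc(OCc2ccccc2)c(C(C)NC(=O)N(C)S(=O)(=O)c2ccccc2)c1`, has not yet been measured. It differs from compound 2 in the same way that compound 3 differs from compound 1, namely (hydrogen in place of chloro on an aromatic carbon), and the place of the change is the same in both pairs, so this is the same change made on a second core.

The expected step is a 1.6-fold higher number from compound 2 to compound 4 (0.21 log units; within the scatter). That expectation rests on the earlier step, an at least 1.2-fold higher number from compound 1 to compound 3 (0.10 log units; that floor lies within the scatter), which ended at the limit of > 200000 nM in this assay, at which 1 of the 3 values shown sits. Starting from compound 2, whose number is already high, the same loss of the chloro group is expected to push the value upward, quite possibly past what the assay can report. Compound 4 is therefore estimated at 230000 nM, with a range from 120000 nM to 450000 nM, and a real chance that only a limit is recorded.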

Compound 4, half-maximal effective concentration: 68200 nM
Beside the measured number, compound 4's estimate is 3.4-fold (0.53 log units) above it; the measured number lies below the stated range.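

In this assay, putting hydrogen in place of the chloro group on the core of compound 2 gives a 2.1-fold lower number from compound 2 to compound 4 (0.32 log units; beyond the scatter), so on this core the number goes down, by a modest step, when the 4-chlorophenyl becomes a phenyl. Compound 3 is recorded only as a limit of the assay, > 200000 nM. This shows that the result on one core cannot simply be assumed for the other, but it does not show that the change truly acts in opposite directions on the two cores, and the comparison stands as follows: the same change on two cores in this assay, an at least 1.2-fold higher number (0.10 log units; that floor lies within the scatter) from compound 1 to compound 3 and a 2.1-fold lower number (0.32 log units; beyond the scatter) from compound 2 to compound 4; the limit leaves it open whether they differ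

The compounds shown leave open how other groups in the same place, such as a fluoro, a methoxy or a nitrile, would behave on either core. Within the data shown here, they also leave open which of the differences between the core of compound 1 and the core of compound 2 matters for this change, since no compound here separates those differences one at a time.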